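Removing the butoxy group from compound 1

This account rests on a few compounds, and the source may have more. Where it says the series, first, only, none or still open, it means among the compounds named here.

Values in a functional assay on SK-BR-3 cells (Homo sapiens) for antiproliferative activity (on this read-out higher numbers stand for weaker inhibition and lower numbers for stronger inhibition), follow.
- compound 1 (`CCCCOc1ccc(C(=O)Nc2cc3ccc(OC4CCN(C)CC4)c(C)c3oc2=O)cc1CC=C(C)C`) gives 1400 nM
- compound 2 (`Cc1c(OC2CCN(C)CC2)ccc2cc(NC(=O)c3ccc(O)c(CCC(C)C)c3)c(=O)oc12`) gives 600 nM
- compound 3 (`Cc1c(OC2CCN(C)CC2)ccc2cc(NC(=O)c3ccc4c(c3)CCC(C)(C)O4)c(=O)oc12`) gives 3460 nM

Compound 1 holds the second highest of the three numbers. Compound 2 lies lower at 600 nM and compound 3 lies higher at 3460 nM, and both gaps from compound 1 go beyond the scatter.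

Compound 4 (`CC(C)=CCc1cccc(C(=O)Nc2cc3ccc(OC4CCN(C)CC4)c(C)c3oc2=O)c1`) has not yet been measured. It carries hydrogen in place of butoxy on an aromatic carbon, ortho to a 3-methylbut-2-en-1-yl group (hydrogen in place of butoxy on an aromatic carbon). Among the measured compounds shown here, no pair of measured compounds differs in one place only, so the data give no direct guide to this change. In this assay a small step toward a higher number is expected, perhaps none beyond the scatter. The estimate is a 1.3-fold higher number from compound 1 to compound 4 (0.11 log units; within the scatter). For compound 4 the estimated value is 1800 nM, with an expected range from 600 nM to 5400 nM.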

Compound 4, half-maximal inhibitory concentration: 1680 nM
Compound 4: the middle estimate sits 1.1-fold (0.03 log units) above what was measured; measured number inside the range.
By their numbers in this assay, from the lowest: compound 2; then compounds 1 and 4 (each within the scatter of the next); then compound 3.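

Among the compounds shown here, replacing butoxy with hydrogen in this assay gives the first single-place step (a 1.2-fold higher number from compound 1 to compound 4 (0.08 log units; within the scatter)). Compound 1 and compound 4 cannot be told apart on this read-out, so on this aromatic carbon, ortho to a 3-methylbut-2-en-1-yl group, the butoxy chain with its 5 heavy atoms can be lost without a change that rises above the scatter of repeated measurements. Nothing available explains this result.

A single step cannot show whether other groups on this carbon, such as a methoxy group, an amine or a carboxylic acid, would be tolerated in the same way. It also leaves open whether butoxy and hydrogen would remain indistinguishable if the 3-methylbut-2-en-1-yl group were replaced.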